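Swapping pyrazin-2-yl for cyclobutyl on an oxygen

This account rests on a few compounds, and the source may have more. Where it says the series, first, only, none or still open, it means among the compounds named here.

In an ADME assay on the whole organism (plasma, Rattus norvegicus) for protein binding, using cassette dosing, at a dose of 1 mg/kg (on this read-out higher numbers stand for a larger free fraction and lower numbers for a smaller free fraction), compound 1 `CC(C)Oc1ccc(/N=c2\[nH]c(=O)n(C[C@@H](C)C(=O)O)c(=O)n2Cc2ccc(Cl)cc2)cc1Cl` gives 0.002 and compound 3 `CC(C)Oc1ccc(Nc2nc(=O)n(CCCO)c(=O)n2Cc2ccc(Cl)cc2)cc1Cl` gives 0.003 as its reading. Compound 2 `C[C@@H](Cn1c(=O)[nH]/c(=N\c2ccc(Oc3cnccn3)cc2)n(Cc2ccc(Cl)cc2)c1=O)C(=O)O` stands highest of the three at 0.018 and lies beyond the usual scatter from both others. Compound 4 `C[C@@H](Cn1c(=O)[nH]/c(=N\c2ccc(OC3CCC3)cc2)n(Cc2ccc(Cl)cc2)c1=O)C(=O)O` differs from compound 2 in one place, with cyclobutyl in place of pyrazin-2-yl on an oxygen on an aromatic ring. Among the compounds with values here, no measured pair shows this change alone, so any step remains a judgement. Compound 1 also carries only carbon in the group on that oxygen and shows 0.002 here, so a clear drop is expected. The expected fall a 4.5-fold lower number from compound 2 to compound 4 (0.65 log units; beyond the scatter) lies beyond the scatter. Compound 4 is estimated at 0.004 with a likely range from 0.0015 to 0.01 on this read-out.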

Compound 4, unbound fraction: 0.015
Beside the measured number, compound 4's estimate is 3.8-fold (0.57 log units) below it; measured number above the stated range.
By their numbers in this assay, from the lowest: compounds 1 and 3 (each within the scatter of the next); then compounds 4 and 2 (each within the scatter of the next).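

In this assay, the swap gives a 1.2-fold lower number from compound 2 to compound 4 (0.08 log units; within the scatter), so cyclobutyl and pyrazin-2-yl on an oxygen on an aromatic ring cannot be told apart on this read-out. This direct pair shows that, with the rest of the molecule held constant, replacing this six-membered aromatic ring containing two nitrogens with a four-membered carbon ring produces no readable step. Nothing measured here explains this result.

As far as these compounds go, whether a piperidinyl group, which carries an amine, or a longer chain such as n-hexyl on that oxygen would also read the same remains open.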